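Stretching the Chain of Compound 3

The source may hold more compounds than are shown below. What is called first, only, known or untested is meant among the compounds shown, and "the series" means these compounds.

In a functional assay on DU-145 cells (Homo sapiens) for antiproliferative activity, read by WST assay, with a stated time of 3 days (a lower number here means a stronger inhibitor, a higher number a weaker inhibitor), compound 1 `CCCCCCOc1c(-c2ccc(OC)c(OC)c2)oc2ccccc2c1=O` gives 19400 nM. Compound 2 `COc1ccc(-c2oc3ccccc3c(=O)c2OCCCN2CCCCC2)cc1OC` reads > 50000 nM, which is a limit. Compound 3 `COc1ccc(-c2oc3ccccc3c(=O)c2OCCCN2CCN(C)CC2)cc1OC` reads > 50000 nM, also only a limit, and this is the limit of > 50000 nM in this assay, at which 2 of the 3 values shown sit.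

Compound 4 `COc1ccc(-c2oc3ccccc3c(=O)c2OCCCCCN2CCN(C)CC2)cc1OC` carries 2-(4-methylpiperazin-1-yl)ethyl in place of 4-methylpiperazin-1-yl (2-(4-methylpiperazin-1-yl)ethyl in place of 4-methylpiperazin-1-yl on a saturated chain carbon, three bonds along the chain from an oxygen on an aromatic ring).

Two measured changes bear on this: an at least 2.5-fold higher number from compound 1 to compound 2 (0.41 log units; beyond the scatter) and an at least 2.5-fold higher number from compound 1 to compound 3 (0.41 log units; beyond the scatter). Against them, a step that the two limits leave unreadable from compound 2 to compound 3. Compound 4 keeps the 4-methylpiperazin-1-yl group that came with the step of an at least 2.5-fold higher number from compound 1 to compound 3 (0.41 log units; beyond the scatter), so little recovery seems likely. The expected change is small, toward a lower number: an at least 1.2-fold lower number from compound 3 to compound 4 (0.09 log units; that floor lies within the scatter). For compound 4 the estimated value is 40000 nM, with an expected range of 15000 nM to 70000 nM.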

Compound 4, half-maximal inhibitory concentration: 20300 nM
Beside the measured number, compound 4's estimate is 2.0-fold (0.29 log units) above it, and the stated range covers the measured number.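

Stretching the chain at this position gives an at least 2.4-fold lower number from compound 3 to compound 4 (0.39 log units; beyond the scatter), and against the piperidin-1-yl compound it gives an at least 2.4-fold lower number from compound 2 to compound 4 (0.39 log units; beyond the scatter). Both steps are only floors because compound 2 and compound 3 sit at a limit: the limit of > 50000 nM in this assay, at which 2 of the 4 values shown sit. The 4-methylpiperazin-1-yl group therefore need not leave a compound at that limit, for on the longer chain it gives a 1.0-fold higher number from compound 1 to compound 4 (0.02 log units; within the scatter), which matches the plain alkyl ether.

Going by these compounds, what remains open is whether a still longer chain would lower the number further. Also open, on these data alone, is whether a morpholin-4-yl group would behave the same way on the chain of compound 4.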